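Removing the dichlorophenyl group from compound 3

The compounds below may be only part of what the source reports. "The series", "measured", "known", "first", "only" and "open" are said of these compounds alone.

Working notes on the series. Among the compounds with values here, compound 3 `Nc1nc(O)c2c(n1)n(C1OC(CO)[C@@H](O)[C@H]1O)c(=O)n2Cc1ccc(Cl)c(Cl)c1` stands highest of the three numbers measured so far: in a functional assay on the whole organism (B cells) with Mus musculus as the target (on this read-out lower numbers stand for smaller maximal responses and higher numbers for larger maximal responses), compound 3 gives 55%. Compound 1 `Nc1nc(O)c2c(n1)n(C1OC(CO)[C@@H](O)[C@H]1O)c(=O)n2CC(O)CSc1ccccc1` gives 12% in this assay, and compound 2 `CC1OC(n2c(=O)n(C)c3c(O)nc(N)nc32)[C@H](O)[C@@H]1O` gives 0%. Within the data shown here, the only single-place step among the measured compounds is a number 43 percentage points higher from compound 1 to compound 3 (beyond the scatter), which shows that the group on the saturated chain carbon bound to the aromatic nitrogen moves the maximal response strongly.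

Compound 4 `Cn1c(=O)n(C2OC(CO)[C@@H](O)[C@H]2O)c2nc(N)nc(O)c21` is not yet measured. It differs from compound 3 by hydrogen in place of 3,4-dichlorophenyl on a saturated chain carbon bound to an aromatic nitrogen, so the large group that separates compound 3 from compound 1 is taken away entirely. Among the measured compounds shown here, the step bearing on this is the one from compound 1 to compound 3, which was large, and it points to the substituent at this place as what carries the response. For the measured compounds named here, compound 2 also carries a methyl at this place but differs from compound 4 in the sugar part, and no step between the two is at hand; it can only be said that compound 2 gives 0% in this assay.

A fall beyond the scatter is therefore expected, of about a number 47 percentage points lower from compound 3 to compound 4 (beyond the scatter). Compound 4 is estimated to give 8%, with a range from 0% to 25%.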

Compound 4, largest response reached (reported as maximal response), in percent of the reference or control that the assay uses: 99%
For compound 4 the middle estimate is 91 percentage points below the measured one; the measured number lies above the stated range.
By their numbers in this assay, from the lowest: compound 2; then compound 1; then compound 3; then compound 4.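

In this assay the change is a number 44 percentage points higher from compound 3 to compound 4 (beyond the scatter) and a number 87 percentage points higher from compound 1 to compound 4 (beyond the scatter), so on a saturated chain carbon bound to an aromatic nitrogen neither 3,4-dichlorophenyl nor 1-hydroxy-2-(phenylsulfanyl)ethyl is needed for a high maximal response, and the plain methyl gives the highest number of the four. The earlier step between the two large groups therefore ranks them against each other and does not show that a large group carries the response, since both stand beneath hydrogen in this place. With methyl at the aromatic nitrogen in both compounds, the change is a number 99 percentage points higher from compound 2 to compound 4 (beyond the scatter), which shows that this methyl does not give the response by itself and that, in this pair, hydroxy in place of hydrogen on a saturated chain carbon bound to a saturated ring carbon decides the outcome.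

No measurement at hand gives a reason for this order. The compounds shown leave open how the response moves with an unsubstituted benzyl, a longer chain such as propyl, or a chain ending in an amine in this place, and so whether the fall from the methyl sets in gradually or only with the largest groups.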